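An exchange on the amide nitrogen of compound 3

The compounds below may be only part of what the source reports. "The series", "measured", "known", "first", "only" and "open" are said of these compounds alone.

Measured in an ADME assay on MT4 cells (Homo sapiens) for cytotoxicity, read by MTT assay; on this read-out lower numbers stand for higher toxicity in this test and higher numbers for lower toxicity in this test:
- compound 1 `Cc1cc(C)cc(S(=O)(=O)c2c(C(=O)NC(C)C(=O)NCCn3c(C)cnc3[N+](=O)[O-])[nH]c3ccc(Cl)cc23)c1` gives 16000 nM
- compound 2 `Cc1cc(C)cc(S(=O)(=O)c2c(C(=O)NC(C)C(=O)NC(C)c3ccccc3)[nH]c3ccc(Cl)cc23)c1` gives 21700 nM
- compound 3 `Cc1cc(C)cc(S(=O)(=O)c2c(C(=O)NCC(=O)NC(C)c3ccncc3)[nH]c3ccc(Cl)cc23)c1` gives 47000 nM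

Compound 3 stands highest of the three, and its gaps to compound 2 and to compound 1 both lie beyond the scatter. Compound 4 `Cc1cc(C)cc(S(=O)(=O)c2c(C(=O)NC(C)C(=O)NCc3ccncn3)[nH]c3ccc(Cl)cc23)c1` differs from compound 3 by one exchange on an amide-type nitrogen: a group of 12 heavy atoms (8 carbon, 3 nitrogen, 1 oxygen; one six-membered aromatic ring with 2 hetero atoms) in place of a group of 12 heavy atoms (9 carbon, 2 nitrogen, 1 oxygen; one six-membered aromatic ring with 1 hetero atom), on an amide-type nitrogen. Going by the values given here, only one measured step also exchanges a ring-bearing group on such a nitrogen, and it is a 1.4-fold higher number from compound 1 to compound 2 (0.13 log units; within the scatter). That step swapped different groups from the present pair, so it is only an indirect guide. Even so, no change beyond the scatter is expected in this assay, with a slight lean towards a lower number, since compound 3 sits at the top and compound 2 gives 21700 nM. The expected step is a 1.6-fold lower number from compound 3 to compound 4 (0.19 log units; within the scatter). Compound 4 is estimated at 30000 nM, with an expected range from 12000 nM to 70000 nM.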

Compound 4, half-maximal cytotoxic concentration: 28100 nM
Compound 4: middle estimate off by 1.1-fold (0.03 log units), on the high side; the range from low to high includes it.
By their numbers in this assay, from the lowest: compounds 1, 2, 4 and 3 (each within the scatter of the next, the first and the last beyond it).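

In this assay, the exchange on the amide-type nitrogen that brings in a six-membered aromatic ring with 2 hetero atoms stays within the scatter (a 1.7-fold lower number from compound 3 to compound 4 (0.22 log units; within the scatter)). The same holds for (pyrimidin-4-yl)methyl in place of 1-phenylethyl (a 1.3-fold higher number from compound 2 to compound 4 (0.11 log units; within the scatter)) and for the six-membered ring group in place of the five-membered one on the saturated chain carbon (a 1.8-fold higher number from compound 1 to compound 4 (0.24 log units; within the scatter)). The earlier compounds shown here left compound 3 set apart from the other two, whereas compound 4 lies within the scatter of all three, so these ring exchanges do not separate it from any of them.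

No measurement at hand accounts for these numbers. On these data alone, whether an amine, a carboxylic acid or a plain alkyl chain in place of these ring-bearing groups would stay in the same range remains open.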